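The source may report more compounds than this note shows. Statements on the series, on what has been measured and on what is new or still open speak of the compounds shown alone.

Measured compounds in an assay on isolated protein for inhibition of Calpain-1 catalytic subunit (Sus scrofa); on this read-out lower numbers stand for stronger inhibition and higher numbers for weaker inhibition:

Compound 1, `O=C(O)/C(S)=C/c1c[nH]c2cc(Cl)ccc12`, gives 100 nM.
Compound 2, `O=C(O)/C(S)=C/c1c[nH]c2ccc(F)cc12`, gives 930 nM.
Compound 3, `O=C(O)/C(S)=C/c1ccccc1Cl`, gives 20700 nM.

Among these three numbers compound 2 stands in the middle, as the second highest. Its nearest neighbour is compound 1, whose number is lower by a gap beyond the usual scatter; compound 3 lies furthest away, with a number that is higher, again beyond the scatter. All three share a carboxylic acid and a thiol on the same double bond; compound 1 and compound 2 carry a fused two-ring core with a halogen on it, while compound 3 carries a single benzene ring with a chloro.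

The unmeasured compound 4, `O=C(O)/C(S)=C/c1c[nH]c2ccc(Br)cc12`, is built from compound 2 by one change: bromo in place of fluoro on an aromatic carbon. Going by the values given here, no measured pair shows this particular exchange, so there is no step to read off directly. What is known is that compound 1, with a chloro on the fused core, gives 100 nM, a lower number than compound 2, though its halogen sits at a different place. On this basis compound 4 is expected to give a somewhat lower number than compound 2, with an expected step of a 2.7-fold lower number from compound 2 to compound 4 (0.42 log units; beyond the scatter) in this assay. The estimate for compound 4 is 350 nM, within a range from 90 nM to 1400 nM.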

Compound 4, half-maximal inhibitory concentration: 20 nM
Compound 4: middle estimate off by 18-fold (1.24 log units), on the high side; measured number below the stated range.
By their numbers in this assay, from the lowest: compound 4; then compound 1; then compound 2; then compound 3.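

In this assay, bromo in place of fluoro on this aromatic carbon of the shared core gives a 47-fold lower number from compound 2 to compound 4 (1.67 log units; beyond the scatter) and is counted as a large step. Going by these compounds alone, this is the first pair here that differs in one place only, and it shows that the read-out at this position depends strongly on which halogen is present, even though the swap exchanges one heavy atom for another and leaves the count of rings, hydrogen-bond donors, hydrogen-bond acceptors and net charge unchanged. No measurement shown here explains why these two halogens differ so much.

Going by these compounds, with only fluoro and bromo at this position, it remains open where a chloro or an iodo at the same place would fall, and whether a methyl, a methoxy or an amine there would give a number closer to that of compound 2 or to that of compound 4. On these data alone, it also remains open whether bromo in place of the chloro of compound 1 would bring a step of similar size at that other place on the core.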